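Swapping nitro for trifluoromethyl on the benzyl ring

The source may hold more compounds than are shown below. What is called first, only, known or untested is meant among the compounds shown, and "the series" means these compounds.

Measured so far:
Compound 1, `O=[N+]([O-])c1ccccc1CNc1cc(Br)cc2[nH]ncc12`, 39000 nM
Compound 2, `O=[N+]([O-])c1cccc(CNc2cc(C(F)(F)F)cc3[nH]ncc23)c1`, 5170 nM
Compound 3, `O=[N+]([O-])c1cccc(CNc2cc(Br)cc3[nH]ncc23)c1`, 1600 nM

All three share one core and differ in the groups hung on it. In an assay for inhibition of Tryptophan 2,3-dioxygenase (Homo sapiens), with stated times of 10 min and 60 min (a higher number here means a weaker inhibitor, a lower number a stronger inhibitor), compound 2 sits second highest of the three numbers; its nearest neighbour is compound 3, and the change between them is a 3.2-fold lower number from compound 2 to compound 3 (0.51 log units; beyond the scatter). Compound 1, with its nitro group on a different carbon of the benzyl ring, gives 39000 nM.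

Compound 4 is `FC(F)(F)c1cccc(CNc2cc(C(F)(F)F)cc3[nH]ncc23)c1`. It differs from compound 2 only on the benzyl ring: trifluoromethyl in place of nitro on an aromatic carbon. Within the data shown here, no measured pair changes the nitro group itself, so nothing in hand bears directly on this step; the one step that is measured, from compound 2 to compound 3, concerns the other ring and says nothing about exchanging nitro for trifluoromethyl. With the two hydrogen-bond acceptors of the nitro group gone and no acceptor entering, the expectation is a modest step, if any, in this assay, with a weaker inhibitor slightly more likely than a stronger one. Compound 4 is therefore estimated at 8000 nM, ranging from 2500 nM to 25000 nM, which means an expected 1.5-fold higher number from compound 2 to compound 4 (0.19 log units; within the scatter).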

Compound 4, half-maximal inhibitory concentration: 12200 nM
The estimate for compound 4 lay 1.5-fold (0.18 log units) below the measured number; measured number inside the range.
By their numbers in this assay, from the lowest: compound 3; then compound 2; then compound 4; then compound 1.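

On the benzyl ring, in this assay, trifluoromethyl in place of nitro gives a 2.4-fold higher number from compound 2 to compound 4 (0.37 log units; beyond the scatter), a modest step but one beyond the usual scatter, so this carbon does respond to what is placed on it. Among these compounds, this is the first measured change to the benzyl substituent with the rest of the molecule held fixed, and it shows that the hydrogen-bond acceptors of the nitro group can leave, with none entering, at the price of a weaker inhibitor but with a measurable number still in hand. Among the compounds shown here, no measurement accompanies this step that could say why the number rises, and the single exchange cannot separate what leaving nitro contributes from what entering trifluoromethyl contributes.

The compounds shown leave open whether the same exchange would give a step of similar size with bromo on the other ring, as in compound 3, where the benzyl ring still carries nitro. They also leave open how a nitrile, a carboxylic acid or an amine on this same carbon would compare with nitro and trifluoromethyl.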